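A few compounds are considered here, and "the series" means these few. Any claim that something is new, unique, unknown or untested is made for them only; others in the source may bear on it.

Values in a functional assay on the whole organism for inhibition, with Mus musculus as the target; a lower number here means that less compound is needed, a higher number that more compound is needed for the effect:
- compound 1 `Cc1ccc(C2CN(C)Cc3c(N)cccc32)cc1`: about 1.2 mg/kg
- compound 2 `CC(C)c1ccc(C2CN(C)Cc3c(N)cccc32)cc1`: 68 mg/kg
- compound 3 `CCNC(=O)Nc1cccc2c1CN(C)CC2c1ccccc1`: 54 mg/kg
- compound 4 `CCCNC(=O)Nc1cccc2c1CN(C)CC2c1ccccc1`: not yet measured

Compound 3 at 54 mg/kg lies within the scatter of compound 2, and far from compound 1. Compound 4 differs from it by methyl in place of hydrogen on a saturated chain carbon, two bonds along the chain from an amide-type nitrogen, which reads as ethyl to propyl. For the measured compounds named here, only one measured step enlarges an alkyl group: a 57-fold higher number from compound 1 to compound 2 (1.75 log units; beyond the scatter). That step is large, but it is isopropyl in place of methyl on an aromatic carbon, not a change on a saturated chain carbon, so it bears only weakly here. It does give a weak hint of direction. In this assay the expected change is small, with no step beyond the scatter: a 1.1-fold higher number from compound 3 to compound 4 (0.05 log units; within the scatter). For compound 4 the estimate is 60 mg/kg, with an expected range of 20 mg/kg to 180 mg/kg.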

Compound 4, dose for half-maximal effect: > 80 mg/kg
Compound 4: only a limit was reported (the forecaster's own chance of this, stated with the estimate: 10%); middle value at least 1.3-fold (0.12 log units) away from the limit.
By their numbers in this assay, from the lowest: compound 1; then compounds 3 and 2 (each within the scatter of the next). At a limit, above all of these: compound 4.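

In this assay compound 4 is reported only as a limit, > 80 mg/kg. For the compounds shown here, earlier compounds showed alkyl enlargement only on an aromatic carbon; this is the first reading for ethyl to propyl on a saturated chain carbon, two bonds along the chain from an amide-type nitrogen. Its step is only a floor, an at least 1.4-fold higher number from compound 3 to compound 4 (0.17 log units; that floor lies within the scatter), so the change may be small or much larger.

Going by these compounds, how far the true number for compound 4 lies past the limit remains open. Also open, on these data alone, is how a butyl chain, or an amine on this chain, would read here.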